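The source may hold more compounds than are shown below. What is called first, only, known or untested is meant among the compounds shown, and "the series" means these compounds.

In a functional assay on SK-BR-3 cells (Homo sapiens) for antiproliferative activity, read by MTT assay, with a stated time of 72 h (a lower number here means a stronger inhibitor, a higher number a weaker inhibitor), compound 1, with the structure `C/C=C1/[C@H](O[C@@H]2O[C@H](CO)[C@@H](O)[C@H](O)[C@H]2O)OC=C(C(=O)OC)[C@H]1CC(=O)OCCC1CCCCC1`, gives 2000 nM. Among the three compounds measured, compound 1 is the only one whose result is reported as a number. Compound 2, with the structure `C/C=C1/[C@H](O[C@@H]2O[C@H](COC(C)=O)[C@@H](OC(C)=O)[C@H](OC(C)=O)[C@H]2OC(C)=O)OC=C(C(=O)O)[C@H]1CC(=O)OC`, reaches only the limit of the assay, > 20000 nM, so no number is known for it. Compound 3, with the structure `C/C=C1/[C@H](O[C@@H]2O[C@H](COC(C)=O)[C@@H](OC(C)=O)[C@H](OC(C)=O)[C@H]2OC(C)=O)OC=C(C(=O)OC)[C@H]1CC(=O)SCCC`, likewise reaches only the limit of the assay, > 15000 nM. No two of these three compounds differ in a single place, so no measured step can be read from them.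

Compound 4, with the structure `C/C=C1/[C@H](O[C@@H]2O[C@H](CO)[C@@H](O)[C@H](O)[C@H]2O)OC=C(C(=O)OC)[C@H]1CC(=O)OCCC`, differs from compound 1 in one place: methyl in place of cyclohexyl on a saturated chain carbon, two bonds along the chain from an oxygen next to a carbonyl group. Cyclohexyl leaves and methyl enters, so that 2-cyclohexylethyl becomes propyl on a saturated chain carbon, two bonds along the chain from an oxygen next to a carbonyl group. For the measured compounds named here, since no measured step of this kind exists here, the expectation rests on compound 1 alone, and the step from compound 1 to compound 4 is expected to be a moderate weakening, a 2.5-fold higher number from compound 1 to compound 4 (0.40 log units; beyond the scatter), though a change within the scatter cannot be excluded. Compound 4 is therefore expected to give about 5000 nM in this assay, within the range 1500 nM to 16000 nM.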

Compound 4, half-maximal inhibitory concentration: > 15000 nM
Compound 4 gave a limit, no number (the forecaster's own chance of this, stated with the estimate: 25%); at least 3.0-fold (0.47 log units) between middle value and limit.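

In this assay compound 4 reaches only a limit of the assay, > 15000 nM, and no number is known for it. Replacing 2-cyclohexylethyl with propyl gives an at least 7.5-fold higher number from compound 1 to compound 4 (0.87 log units; beyond the scatter), the first single change shown at this place, and it shows that antiproliferative activity in these cells is sensitive to what sits on this chain: with the cyclohexyl present there is a measurable value, and without it the result falls to the limit. The printed step is only a minimum, and the true size of the loss remains unknown, as compound 4 sits at a limit of the assay: the limit of > 15000 nM in this assay, at which 2 of the 4 values shown sit.

As far as these compounds go, it remains open whether the cyclohexyl ring itself is what counts or mainly the length of the group, a question that a longer open chain such as hexyl, or a phenyl ring, at this place would help to answer. From the compounds shown here alone, it also remains open how an amine or a carboxylic acid at the end of this chain would compare with compound 1 in this assay.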